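The source may hold more compounds than are shown below. What is called first, only, known or untested is meant among the compounds shown, and "the series" means these compounds.

Measured compounds:
Compound 1 `CC1=CC[C@@H]([C@@](C)(O)CCCC(C)(C)NC=S)CC1`: 72000 nM
Compound 2 `COc1ccc(/C=N\NC(=S)NC(C)(C)CCC[C@](C)(O)[C@@H]2CC=C(C)CC2)cc1`: 76100 nM

Compound 2 `COc1ccc(/C=N\NC(=S)NC(C)(C)CCC[C@](C)(O)[C@@H]2CC=C(C)CC2)cc1` gives the highest of the two numbers in a functional assay on PCO3 cells (Homo sapiens) for cytotoxicity, read by sulforhodamine B assay (on this read-out lower numbers stand for stronger inhibition of growth and higher numbers for weaker inhibition of growth), yet its value stands within the scatter of compound 1, so the two cannot be ranked. Compound 3 `CC1=CC[C@@H]([C@@](C)(O)CCCC(C)(C)NC(=S)N/N=C\c2ccc([N+](=O)[O-])cc2)CC1` differs from compound 2 by nitro in place of methoxy on an aromatic carbon. Among the measured compounds shown here, no measured pair shows such a change, so the expectation rests on the two values alone. A small step of a 1.3-fold lower number from compound 2 to compound 3 (0.10 log units; within the scatter) toward stronger growth inhibition is expected, staying within scatter. Compound 3 is expected to give 60000 nM, in the range 25000 nM to 150000 nM.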

Compound 3, concentration for total growth inhibition: > 100000 nM
Compound 3 ended at the assay's limit; the forecaster's own chance of this, stated with the estimate: 10%; middle value at least 1.6-fold (0.22 log units) from the limit.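

At this place on the aromatic ring, para to a large group, nitro in place of methoxy gives an at least 1.3-fold higher number from compound 2 to compound 3 (0.11 log units; that floor lies within the scatter) in this assay. Compound 3 gives > 100000 nM, which is a limit of the assay and not a number. The change therefore shows no move toward stronger inhibition of growth, but its true size cannot be read, and only a floor is available: the limit of > 100000 nM in this assay, at which 1 of the 3 values shown sits.

As far as these compounds go, how far compound 3 really lies from compound 2 stays open. Also open, from the compounds shown here alone, is what an amine or a carboxylic acid on this aromatic carbon would give.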